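Heteroaryl swaps on the shared core: estimate for compound 4

This account rests on a few compounds, and the source may have more. Where it says the series, first, only, none or still open, it means among the compounds named here.

Measured compounds and their values in a functional assay on HEK293 cells for agonist activity at Bombesin receptor subtype-3 (Mus musculus), read by luminescence and calcium flux, with a stated time of 10 min; on this read-out lower numbers stand for an effect already at smaller amounts and higher numbers for an effect only at larger amounts of compound:
compound 1, `CCC(C)(C)Cc1c[nH]c(CCc2ccc(-c3csnn3)cc2)n1`, 109 nM
compound 2, `CCC(C)(C)Cc1c[nH]c(CCc2ccc(-c3cnccn3)cc2)n1`, 107 nM
compound 3, `CCC(C)(C)Cc1c[nH]c(CCc2ccc(-n3ncnn3)cc2)n1`, 99 nM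

Compound 1 carries the largest of the three numbers, but only by steps that lie within the scatter: a 1.0-fold lower number from compound 1 to compound 2 (0.01 log units; within the scatter) and a 1.1-fold lower number from compound 1 to compound 3 (0.04 log units; within the scatter). The remaining pair is likewise flat, a 1.1-fold lower number from compound 2 to compound 3 (0.03 log units; within the scatter). Across three different heteroaryl groups at the same place, the read-out in this assay has not moved.

Compound 4, `CCC(C)(C)Cc1c[nH]c(CCc2ccc(-n3cccn3)cc2)n1`, is not yet measured. It differs from compound 1 in one place: 1H-pyrazol-1-yl in place of 1,2,3-thiadiazol-4-yl on an aromatic carbon. Going by the values given here, the steps that bear on this change are those between compound 1, compound 2 and compound 3, each a swap of one heteroaryl group for another at this position, and none of them reached beyond the scatter. On that basis no step beyond the scatter is expected in this assay for compound 4, in either direction, which is what a 1.0-fold lower number from compound 1 to compound 4 (0.02 log units; within the scatter) means. The expected value for compound 4 in this assay is 105 nM, with a range from 55 nM to 210 nM.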

Compound 4, half-maximal effective concentration: 113 nM
For compound 4 the middle estimate is 1.1-fold (0.03 log units) below the measured one; measured number inside the range.
By their numbers in this assay, from the lowest: compounds 3, 2, 1 and 4 (each within the scatter of the next).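

In this assay the pyrazolyl group fits the flat picture, with each new step inside the scatter: 1H-pyrazol-1-yl for 1,2,3-thiadiazol-4-yl gives a 1.0-fold higher number from compound 1 to compound 4 (0.02 log units; within the scatter), for the 2H-tetrazol-2-yl group a 1.1-fold higher number from compound 3 to compound 4 (0.06 log units; within the scatter), and for the pyrazin-2-yl group a 1.1-fold higher number from compound 2 to compound 4 (0.02 log units; within the scatter) and no more. The position on the six-membered aromatic ring of carbon only, para to a large group, therefore accepts a fourth heteroaryl group without a readable shift, and the change from a five-membered aromatic ring with 3 hetero atoms, one of them sulfur, to one with 2 hetero atoms and no sulfur leaves the read-out in place. No supporting data bear on why this position is so insensitive.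

All four groups are aromatic rings, so the compounds shown leave open whether an amine, a carboxylic acid or a saturated morpholine ring at this place would hold the read-out equally flat. They also leave open whether an unsubstituted phenyl ring, with no hetero atoms at all, would do the same.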